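A Single Measured Value and One Group Exchanged

A few compounds are considered here, and "the series" means these few. Any claim that something is new, unique, unknown or untested is made for them only; others in the source may bear on it.

In a functional assay on MDA-MB-231 cells (Homo sapiens) for antiproliferative activity, read by MTT assay, with a stated time of 72 h (on this read-out lower numbers stand for stronger inhibition and higher numbers for weaker inhibition), compound 1 `NC1=NC2(CCSCC2)N(OCCCOc2cccc(Cl)c2)C(N)=N1` gives 130 nM. Within the data shown here, this is the only number available for the series, so compound 1 cannot yet be ranked as strong or weak against any close relative. Compound 2 `Cc1ccc(OCCCON2C(N)=NC(N)=NC23CCOCC3)cc1` offers nothing to compare: in this assay compound 2 has the entry "not determined" (no result reported).

The next molecule to be measured is compound 3 `COc1ccc(OCCCON2C(N)=NC(N)=NC23CCSCC3)cc1`. It carries 4-methoxyphenyl in place of 3-chlorophenyl on an oxygen on a saturated carbon. The rest of the molecule stays the same.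

Among the measured compounds shown here, no measured pair shows what an exchange of this kind does in this assay, so any forecast here is a judgement with a wide margin. The expectation is a small loss of activity, meaning a somewhat higher number, and the true step could still fall within the usual scatter. Put as a change, the estimate is a 2.3-fold higher number from compound 1 to compound 3 (0.36 log units; beyond the scatter). For compound 3 the expected value is 300 nM, with an estimated range from 80 nM to 1100 nM.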

Compound 3, half-maximal inhibitory concentration: 350 nM
Beside the measured number, compound 3's estimate is 1.2-fold (0.07 log units) below it; measured number inside the range.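

In this assay, among these compounds, the exchange of 3-chlorophenyl for 4-methoxyphenyl on an oxygen on a saturated carbon gives a 2.7-fold higher number from compound 1 to compound 3 (0.43 log units; beyond the scatter) and so provides the first measured step at this position, showing that the group at the end of the chain can change the number by a modest amount beyond the usual scatter while the rest of the molecule stays the same. This single step does not separate the two differences within the exchange: the group on the aromatic ring changes from chloro to methoxy, and the numbered place in the group name changes from 3 to 4, with the entering group also counting one hydrogen-bond acceptor where the leaving group counts none. No measurement shown here gives a reason for the step, which therefore stands as an observation only.

The compounds shown leave open whether the loss follows the change of group or the change of place, a question that 4-chlorophenyl or 3-methoxyphenyl at this position could help to settle. They also leave open how an unsubstituted phenyl, or a ring bearing an amine or a carboxylic acid, would compare with the two groups measured so far.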